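From a Fluorophenyl to a Dimethylphenyl Substituent

A few compounds are considered here, and "the series" means these few. Any claim that something is new, unique, unknown or untested is made for them only; others in the source may bear on it.

Compound 3 `CCC1=C(O)c2c(oc(-c3cccc(F)c3)cc2=O)C(CC)(CC)C1=O` gives 3.09 uM in a functional assay on KBVIN cells (Homo sapiens) for antiproliferative activity, read by sulforhodamine B assay, with a stated time of 3 days (a lower number here means that less compound is needed, a higher number that more compound is needed for the effect), the lowest of the three numbers measured, though none of its gaps to the other two compounds exceeds the scatter. Compound 1 `CCC1=C(O)c2c(oc(-c3ccc(COC)cc3)cc2=O)C(CC)(CC)C1=O` gives 3.4 uM, and the step of a 1.1-fold lower number from compound 1 to compound 3 (0.04 log units; within the scatter) is within the scatter. Compound 2 `CCC1=C(O)c2c(oc(-c3cccc(C(F)(F)F)c3)cc2=O)C(CC)(CC)C1=O` gives 5.42 uM, and the step of a 1.8-fold lower number from compound 2 to compound 3 (0.24 log units; within the scatter) is likewise within the scatter. Compound 4 `CCC1=C(O)c2c(oc(-c3cccc(C)c3C)cc2=O)C(CC)(CC)C1=O` differs from compound 3 by 2,3-dimethylphenyl in place of 3-fluorophenyl on an aromatic carbon. Both measured steps exchange the aryl group on the same carbon and both stay within the scatter, so for compound 4 no step beyond the scatter is expected in this assay, the expected step being a 1.1-fold higher number from compound 3 to compound 4 (0.05 log units; within the scatter). Compound 4 is therefore estimated at 3.5 uM, with a range from 1.5 uM to 8 uM.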

Compound 4, concentration for half-maximal effect: 0.85 uM
Compound 4: the middle estimate sits 4.1-fold (0.61 log units) above what was measured; measured number below the stated range.
By their numbers in this assay, from the lowest: compound 4; then compounds 3, 1 and 2 (each within the scatter of the next).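

In this assay, exchanging the aryl group on this carbon of the shared core now moves the number beyond the scatter, which neither earlier step did: 2,3-dimethylphenyl gives a 3.6-fold lower number from compound 3 to compound 4 (0.56 log units; beyond the scatter) and a 4.0-fold lower number from compound 1 to compound 4 (0.60 log units; beyond the scatter). So this position does respond to the aryl group it carries, though both steps are modest. Nothing available accounts for this change. The compounds shown do not separate the contribution of each methyl group of 2,3-dimethylphenyl. They also leave open how an aryl group bearing an amine or a carboxylic acid would behave here.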